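The source may report more compounds than this note shows. Statements on the series, on what has been measured and on what is new or still open speak of the compounds shown alone.

Measured compounds:
- Compound 1 `COC(=O)N[C@H](C(=O)N1CCC[C@H]1C(=O)Nc1ccc([C@H]2CC[C@H](c3ccc(NC(=O)[C@@H]4CCCN4C(=O)[C@@H](NC(=O)OC)C(C)C)cc3)N2c2ccc(C(F)(F)F)cc2)cc1)C(C)C`: 4.83 mL/min/kg
- Compound 2 `COC(=O)N[C@H](C(=O)N1CCC[C@H]1C(=O)Nc1ccc([C@@H]2CC[C@@H](c3ccc(NC(=O)[C@@H]4CCCN4C(=O)[C@@H](NC(=O)OC)C(C)C)cc3)N2c2ccc(F)cc2)cc1)C(C)C`: 15 mL/min/kg

Among the compounds with values here, in an ADME assay on the whole organism for pharmacokinetics, with Rattus norvegicus as the target, at a dose of 3 mg/kg by the intravenous route (a higher number here means faster removal of the compound, a lower number slower removal), compound 2 gives 15 mL/min/kg, the higher of the two numbers known so far; compound 1, the only comparison, gives 4.83 mL/min/kg, a difference that lies beyond the usual scatter. Compound 3 `COC(=O)N[C@H](C(=O)N1CCC[C@H]1C(=O)Nc1ccc([C@H]2CC[C@H](c3ccc(NC(=O)[C@@H]4CCCN4C(=O)[C@@H](NC(=O)OC)C(C)C)cc3)N2c2ccc(F)cc2)cc1)C(C)C` has not been measured in this assay. It is built from compound 2 by a change in configuration only: the two compounds have the same atoms and bonds and differ only in configuration as drawn: 2 of 6 stereo elements differ; a stereocentre at a saturated ring carbon is drawn S in compound 2 and R in compound 3; a stereocentre at a saturated ring carbon is drawn S in compound 2 and R in compound 3. Within the data shown here, no measured pair shows what such a flip of two saturated ring carbons does to clearance here, so the direction is open. Given that compound 2 gives 15 mL/min/kg and compound 1 gives 4.83 mL/min/kg, the two known numbers set a plausible window, and a modest step toward slower removal is expected, a 1.9-fold lower number from compound 2 to compound 3 (0.27 log units; within the scatter), though a step of no more than the scatter would not surprise. Compound 3 is estimated at 8 mL/min/kg, with a range from 3.5 mL/min/kg to 20 mL/min/kg.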

Compound 3, clearance: 2.17 mL/min/kg
Estimate against measurement, compound 3: 3.7-fold (0.57 log units) above, outside the stated range (below it).
By their numbers in this assay, from the lowest: compound 3; then compound 1; then compound 2.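

In this assay, configuration alone turns out to matter at the two saturated ring carbons, with a 6.9-fold lower number from compound 2 to compound 3 (0.84 log units; beyond the scatter) as the result of flipping both. This step can be credited to those two stereocentres and to nothing else, because the structures leave no other difference: the fact that compounds 2 and 3 differ only in the configuration as drawn. Within the data shown here, compound 3 also gives the first comparison that changes only the aromatic substituent, where fluoro in place of trifluoromethyl on an aromatic carbon runs the other way round, with a 2.2-fold lower number from compound 1 to compound 3 (0.35 log units; beyond the scatter) as the modest step toward fluoro.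

Which of the two stereocentres carries the effect stays open, as they appear here only flipped together. Also open, as far as these compounds go, is how a chloro group or a nitrile on that aromatic carbon would behave, and whether the fluoro and trifluoromethyl comparison holds in the other configuration.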